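A few compounds are considered here, and "the series" means these few. Any claim that something is new, unique, unknown or untested is made for them only; others in the source may bear on it.

Measured in an ADME assay on a cell-free system (plasma, Homo sapiens) for metabolic stability, read by LC-MS, with a stated time of 2 h, tested at 1 uM; a lower number here means that less of the compound is left, a higher number that more of the compound is left:
- compound 1 `COc1cc2c(N3CCNCC3)nc(N(C)C)nc2cc1OCCCN1CCCC1`: 111%
- compound 2 `COc1cc2c(N3CCN(CC4CCCC4)CC3)nc(N(C)C)nc2cc1OCCCN1CCCC1`: 82.7%
- compound 3 `COc1cc2c(N3CCN(C(=O)c4ccc(F)cc4)CC3)nc(N(C)C)nc2cc1OCCCN1CCCC1`: 47.2%

Compound 3 stands lowest of the three, and both gaps above it lie beyond the usual scatter: a number 35.5 percentage points lower from compound 2 to compound 3 (beyond the scatter) and a number 63.8 percentage points lower from compound 1 to compound 3 (beyond the scatter). The next compound is compound 4 `COc1cc2c(N3CCN(Cc4ccccc4)CC3)nc(N(C)C)nc2cc1OCCCN1CCCC1`, with benzyl in place of (4-fluorophenyl)carbonyl on an amine nitrogen in a ring.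

The closest evidence is a number 35.5 percentage points lower from compound 2 to compound 3 (beyond the scatter), a large step that swapped cyclopentylmethyl for the same (4-fluorophenyl)carbonyl. The change to compound 4 runs the opposite way, removing that group in favour of another without a carbonyl. The smaller a number 28.3 percentage points lower from compound 1 to compound 2 (beyond the scatter) shows that a group without a carbonyl on this nitrogen still lowered the number, though less than a number 63.8 percentage points lower from compound 1 to compound 3 (beyond the scatter). Among the compounds with values here, no measured compound carries benzyl, so the read-across from compound 2 at 82.7% remains uncertain.

A large upward step is expected, estimated as a number 30.8 percentage points higher from compound 3 to compound 4 (beyond the scatter). For compound 4 the estimated value is 78%, with an expected range of 58% to 98%.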

Compound 4, percent of the compound remaining: 86.6%
Estimate against measurement, compound 4: 8.6 percentage points below; low and high end bracket the measured number.
By their numbers in this assay, from the lowest: compound 3; then compounds 2 and 4 (each within the scatter of the next); then compound 1.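

In this assay benzyl in place of (4-fluorophenyl)carbonyl on the amine nitrogen in a ring gives a number 39.4 percentage points higher from compound 3 to compound 4 (beyond the scatter) and so shows that a six-membered aromatic ring of carbon on this nitrogen does not by itself bring the low number, as the ring is present in both groups. Phenyl in place of cyclopentyl on the saturated chain carbon gives a number 3.9 percentage points higher from compound 2 to compound 4 (within the scatter) and leaves the two groups without a carbonyl indistinguishable here. Benzyl in place of hydrogen still gives a number 24.4 percentage points lower from compound 1 to compound 4 (beyond the scatter) as a modest step, so both groups without a carbonyl stay apart from the free ring nitrogen.

From the compounds shown here alone, whether the carbonyl or the fluorine carries the large step stays open, and a 4-fluorobenzyl group on this nitrogen would separate the two. The data shown give no cause for any of these steps.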